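Ring enlargement on the thiocarbonyl carbon of compound 1

The compounds below may be only part of what the source reports. "The series", "measured", "known", "first", "only" and "open" are said of these compounds alone.

Compound 1 `CCCCCCCCCCCCCCCCOP(=O)(O)OCCSC(=S)N1CCCCC1` carries the longest chain in this set. In a functional assay on MDA-MB-231 cells (Homo sapiens) for inhibition, read by MTT assay, with stated times of 18 h and 4 h (a higher number here means a weaker inhibitor, a lower number a stronger inhibitor), compound 1 gives 100000 nM, the highest of the three numbers measured, with compound 2 `CCCCCCOP(=O)(O)OCCSC(=S)N1CCCCC1` close by at 85000 nM and compound 3 `CCCCCCCCOP(=O)(O)OCCSC(=S)N1CCCCC1` furthest off at 11900 nM. The step of a 1.2-fold lower number from compound 1 to compound 2 (0.07 log units; within the scatter) stays within the scatter, whereas an 8.4-fold lower number from compound 1 to compound 3 (0.92 log units; beyond the scatter) and a 7.1-fold lower number from compound 2 to compound 3 (0.85 log units; beyond the scatter) are both modest but beyond it; every one of these steps alters only the chain on the phosphate oxygen.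

Compound 4 `CCCCCCCCCCCCCCCCOP(=O)(O)OCCSC(=S)N1CCCCCC1` differs from compound 1 elsewhere: azepan-1-yl in place of piperidin-1-yl on a thiocarbonyl carbon. Going by the values given here, none of the measured steps touches the ring on the thiocarbonyl carbon, so there is no direct precedent for this change in this assay. The shared core with its long chain has so far given the highest numbers in the set, and a one-atom ring enlargement on the thiocarbonyl carbon gives no reason from the data to expect a departure beyond the scatter. The number for compound 4 is therefore estimated to stay close to that of compound 1, with no change at the digits printed from compound 1 to compound 4 (within the scatter) expected to be within the scatter. Compound 4 is estimated at 100000 nM, with a range from 40000 nM to 250000 nM.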

Compound 4, half-maximal inhibitory concentration: > 100000 nM
Compound 4: a limit, no number (the forecaster's own chance of this, stated with the estimate: 25%); the middle value sits exactly at the limit.
By their numbers in this assay, from the lowest: compound 3; then compounds 2 and 1 (each within the scatter of the next).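

On the thiocarbonyl carbon, compound 4 gives > 100000 nM in this assay, and this value is a limit of the assay, not a number. The ring change, azepan-1-yl in place of piperidin-1-yl, reads as a number no lower from compound 1 to compound 4 (the limit leaves the size open), so this position now has a direct comparison in the series, although only its direction can be read. Earlier steps altered only the chain on the phosphate oxygen, whereas this one shows that with the long chain kept, enlarging the ring on the thiocarbonyl carbon brings no lower number, and the reading ends at the limit of the assay: the limit of > 100000 nM in this assay, at which 1 of the 4 values shown sits.

The compounds shown leave open whether azepan-1-yl would shift the number on the shorter chain of compound 3, which gives 11900 nM and so offers a measured value to compare against. They also leave open how a smaller pyrrolidin-1-yl ring, or a morpholin-4-yl ring carrying an oxygen, would read on the same thiocarbonyl carbon.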